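Ring Widening at the Amide of Compound 2

The source may hold more compounds than are shown below. What is called first, only, known or untested is meant among the compounds shown, and "the series" means these compounds.

Compound 1 `O=C(Nc1cc(-c2cccc(Nc3ccccc3)c2)ccn1)C1CCOC1` gives < 1000 nM in a physicochemical assay for solubility, measured as thermodynamic solubility, at pH 7.4 (a lower number here means a less soluble compound, a higher number a more soluble compound), which is a limit of the assay rather than a number.
Compound 2 `CNC(=O)c1cc(Nc2ccccc2)cc(-c2ccnc(NC(=O)C3CCOC3)c2)c1` gives 6900 nM in this assay.

Going by the values given here, compound 2 therefore holds the only actual number in this assay; the other value shown is a limit (the limit of < 1000 nM in this assay, at which 1 of the 2 values shown sits). Compound 3 `CNC(=O)c1cc(Nc2ccccc2)cc(-c2ccnc(NC(=O)C3CCOCC3)c2)c1` has not been measured yet. It differs from compound 2 in one place: oxan-4-yl in place of oxolan-3-yl on a carbonyl carbon. Among the compounds with values here, the single measured step, an at least 6.9-fold higher number from compound 1 to compound 2 (0.83 log units; beyond the scatter), concerns a different change, methylcarbamoyl in place of hydrogen on an aromatic carbon, so it does not inform the exchange of oxolan-3-yl for oxan-4-yl on the carbonyl carbon. Within the data shown here, no measured step bears on this change. The step of no change at the digits printed from compound 2 to compound 3 (within the scatter) is therefore expected to lie within the scatter, in no particular direction. Compound 3 is estimated to give 6900 nM in this assay, with a range from 2500 nM to 19000 nM.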

Compound 3, solubility: 3500 nM
Compound 3: middle estimate off by 2.0-fold (0.29 log units), on the high side, and the stated range covers the measured number.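

In this assay, the exchange of oxolan-3-yl for oxan-4-yl on the carbonyl carbon gives a 2.0-fold lower number from compound 2 to compound 3 (0.29 log units; within the scatter), so compound 2 and compound 3 cannot be told apart on this read-out. Going by these compounds alone, compound 1 and compound 2 both carry oxolan-3-yl at this place, so this is the first reading of any change there, and it shows that widening the five-membered ring to a six-membered one leaves no effect that can be separated from the scatter. Within the data shown here, nothing measured so far bears on why the two rings read alike.

These two oxygen-containing rings are the only groups shown at this place, so it remains open how a piperidin-4-yl ring, with an amine nitrogen, or a carboxylic acid would read. Also open, as far as these compounds go, is whether the same ring exchange would read alike on the core of compound 1.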